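Oxidation of the benzylic alcohol in the azetidine series

This account rests on a few compounds, and the source may have more. Where it says the series, first, only, none or still open, it means among the compounds named here.

Within the data shown here, compound 2 `O=C1O[C@@H](Cn2ccnn2)CN1c1ccc(-c2ccc(C(O)C3CNC3)nc2)c(F)c1` gives 58000 nM in an assay for inhibition of Amine oxidase [flavin-containing] A (Homo sapiens) (a higher number here means a weaker inhibitor, a lower number a stronger inhibitor), and holds the highest of the two numbers so far; the nearest is compound 1 `CN1CCN(CCCC(O)c2ccc(-c3ccc(N4C[C@H](Cn5ccnn5)OC4=O)cc3F)cn2)CC1` with 41000 nM in this assay, and the step of a 1.4-fold higher number from compound 1 to compound 2 (0.15 log units; within the scatter) stays within the scatter. Compound 3 `O=C(c1ccc(-c2ccc(N3C[C@H](Cn4ccnn4)OC3=O)cc2F)cn1)C1CNC1` carries (azetidin-3-yl)carbonyl in place of (azetidin-3-yl)(hydroxy)methyl on an aromatic carbon. Among the measured compounds shown here, no measured step touches this change: the only step known, from compound 1 to compound 2, alters the other substituent on the same saturated carbon and is itself within the scatter. With nothing to lean on beyond that, no step beyond the scatter is expected for this assay in either direction, so the estimate for compound 3 is 55000 nM, a step of a 1.1-fold lower number from compound 2 to compound 3 (0.02 log units; within the scatter), with a range from 18000 nM to 170000 nM to cover the uncertainty of an unprecedented change.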

Compound 3, inhibition constant: 4500 nM
Compound 3: middle estimate off by 12-fold (1.09 log units), on the high side; measured number below the stated range.
By their numbers in this assay, from the lowest: compound 3; then compounds 1 and 2 (each within the scatter of the next).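

Among these compounds, the group on the aromatic carbon next to the ring nitrogen matters in this assay: (azetidin-3-yl)carbonyl in place of (azetidin-3-yl)(hydroxy)methyl gives the first step beyond the scatter (a 13-fold lower number from compound 2 to compound 3 (1.11 log units; beyond the scatter)). The azetidine ring stays in place here, and only the hydroxy-bearing carbon becomes a carbonyl, whereas the change of chain on the alcohol carbon stayed within the scatter; against the longer 1-hydroxy-4-(4-methylpiperazin-1-yl)butyl group the carbonyl compound also separates (a 9.1-fold lower number from compound 1 to compound 3 (0.96 log units; beyond the scatter)). Nothing available bears on the reason for this step.

From the compounds shown here alone, whether the carbonyl keeps this effect with a 3-(4-methylpiperazin-1-yl)propyl group in place of the azetidin-3-yl group remains open. So does how an amine or a plain methylene on that carbon would compare with the alcohol and the carbonyl.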